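Adding a methyl to a short chain in two sulfonate esters

The compounds below may be only part of what the source reports. "The series", "measured", "known", "first", "only" and "open" are said of these compounds alone.

Compound 1 `CCC(=O)Nc1ccc(S(=O)(=O)Oc2ccccc2I)cc1` is the starting point. In a functional assay on MCF7 cells (Homo sapiens) for antiproliferative activity, read by sulforhodamine B assay, with a stated time of 48 h (a higher number here means a weaker inhibitor, a lower number a stronger inhibitor), compound 1 gives 8100 nM. Compound 2 `CC(C)C(=O)Nc1ccc(S(=O)(=O)Oc2ccccc2I)cc1` carries one more carbon than compound 1: the change is methyl in place of hydrogen on a saturated chain carbon bound to a carbonyl carbon and a saturated chain carbon. In this assay compound 2 gives 8100 nM. The measured step of no change at the digits printed from compound 1 to compound 2 (within the scatter) shows that this addition left the number essentially where it was.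

Compound 3 `CCNC(=O)Nc1ccc(S(=O)(=O)Oc2ccccc2C(C)C)cc1` belongs to a different core; how its core differs from that of compound 1 is not broken down here. In this assay compound 3 gives 10000 nM, which sits within the scatter of the numbers for compound 1 and compound 2.

Compound 4 `CCCNC(=O)Nc1ccc(S(=O)(=O)Oc2ccccc2C(C)C)cc1` has not yet been measured. It differs from compound 3 by methyl in place of hydrogen on a saturated chain carbon, two bonds along the chain from an amide-type nitrogen. This is the same kind of change as that from compound 1 to compound 2, though not the same: there the methyl entered on a saturated chain carbon bound to a carbonyl carbon and a saturated chain carbon, whereas here it enters on a saturated chain carbon, two bonds along the chain from an amide-type nitrogen. Because the earlier step of no change at the digits printed from compound 1 to compound 2 (within the scatter) was flat, the step of no change at the digits printed from compound 3 to compound 4 (within the scatter) is expected to be small as well. Compound 4 is therefore estimated at 10000 nM, most likely between 5000 nM and 22000 nM.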

Compound 4, half-maximal inhibitory concentration: 2700 nM
Beside the measured number, compound 4's estimate is 3.7-fold (0.57 log units) above it, outside the stated range (below it).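

On the core of compound 3, lengthening ethylamino to propylamino did move the number in this assay, giving a 3.7-fold lower number from compound 3 to compound 4 (0.57 log units; beyond the scatter). Set beside the flat step on the core of compound 1, this shows that the same kind of change, a methyl in place of a hydrogen, does not carry the same size of effect from one core to the other in these compounds: the same change on two cores in this assay, no change at the digits printed (within the scatter) from compound 1 to compound 2 and a 3.7-fold lower number (0.57 log units; beyond the scatter) from compound 3 to compound 4, 3.7-fold (0.57 log units) apart, beyond the scatter of two such steps. It does not show why the two steps differ, since each core contributes a single pair and the methyl enters at a different kind of carbon in each, so the core and the place of the methyl cannot be told apart here.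

As far as these compounds go, whether a longer chain than propylamino, such as butylamino, would lower the number further on the core of compound 3 remains open. So does what a hydroxyl or an amine in place of the added methyl would do on either core.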